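Replacing the silicon group with 4-(hydroxymethyl)-1H-1,2,3-triazol-1-yl

This account rests on a few compounds, and the source may have more. Where it says the series, first, only, none or still open, it means among the compounds named here.

Compound 1 `CC(C)=CCC[C@]1(C)/C=C/[C@@H](OC(=O)C=C(C)C)[C@](C)(O)/C=C/C(=O)/C(CN(C(C)C)C(C)C)=C\C1` gives 740 nM
Compound 2 `CC[Si](CC)(CC)C/C1=C/C[C@](C)(CCC=C(C)C)/C=C/[C@@H](OC(=O)C=C(C)C)[C@](C)(O)/C=C/C1=O` gives 2810 nM

Going by the values given here, in a functional assay on HL-60 cells (Homo sapiens) for antiproliferative activity, read by MTT assay, with a stated time of 48 h (a lower number here means a stronger inhibitor, a higher number a weaker inhibitor), compound 2 holds the higher of the two numbers, which makes it the weaker inhibitor, and compound 1 is its only neighbour. Compound 3 `CC(C)=CCC[C@]1(C)/C=C/[C@@H](OC(=O)C=C(C)C)[C@](C)(O)/C=C/C(=O)/C(Cn2cc(CO)nn2)=C\C1` differs from compound 2 on a saturated chain carbon bound to a double-bonded ring carbon: a group of 7 heavy atoms (3 carbon, 3 nitrogen, 1 oxygen; one five-membered aromatic ring with 3 hetero atoms) in place of a group of 7 heavy atoms (6 carbon, 1 silicon; no ring), on a saturated chain carbon bound to a double-bonded ring carbon. Among the compounds with values here, one measured step bears on this place, and it is modest but beyond the scatter: a 3.8-fold higher number from compound 1 to compound 2 (0.58 log units; beyond the scatter). Within the data shown here, that step involved a different pair of groups, and no measured compound carries the new ring, so it shows only that this place can move the number. A modest move back toward compound 1 at 740 nM is therefore expected, with low confidence. The expected step is a 1.9-fold lower number from compound 2 to compound 3 (0.27 log units; within the scatter) in this estimate. For compound 3 the estimated value is 1500 nM with an expected range from 450 nM to 5000 nM in this assay.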

Compound 3, half-maximal inhibitory concentration: 3200 nM
Beside the measured number, compound 3's estimate is 2.1-fold (0.33 log units) below it; measured number inside the range.
By their numbers in this assay, from the lowest: compound 1; then compounds 2 and 3 (each within the scatter of the next).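

Putting 4-(hydroxymethyl)-1H-1,2,3-triazol-1-yl in place of the silicon group gives a 1.1-fold higher number from compound 2 to compound 3 (0.06 log units; within the scatter) in this assay, so two groups that share no ring and no hydrogen-bond donors or acceptors cannot be told apart here. Set against diisopropylamino, the same triazole gives a 4.3-fold higher number from compound 1 to compound 3 (0.64 log units; beyond the scatter), which leaves compound 1 as the strongest inhibitor of the three and shows that the position does not respond to every replacement of that group in a graded way. Nothing available explains why diisopropylamino stands apart from the other two groups.

Going by these compounds, it remains open whether other amines, such as dimethylamino or piperidin-1-yl, would keep the number of compound 1. On these data alone, it is also open whether a triazole carrying a carboxylic acid or a longer chain instead of hydroxymethyl would move the number of compound 3.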